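Lengthening the Amine Linker from Compound 2 to Compound 3

A few compounds are considered here, and "the series" means these few. Any claim that something is new, unique, unknown or untested is made for them only; others in the source may bear on it.

Of the compounds shown here, two sharing one core have been measured in a functional assay on cells (Homo sapiens) for cytotoxicity, read by MTT assay, with a stated time of 48 h; a lower number here means a stronger inhibitor, a higher number a weaker inhibitor. Compound 1, `CN(C)CCCCCN(C)C1=Nc2ccccc2C(CC(=O)NCc2ccccc2)N1c1ccc(-c2ccccn2)cc1`, reached only the limit of this assay, reported as > 5000 nM. Compound 2, `CN(C)CCCCN(C)C1=Nc2ccccc2C(CC(=O)NCc2ccccc2)N1c1ccc(-c2ccccc2)cc1`, gave 3970 nM in this assay. Within the data shown here, compound 2 therefore holds the only actual number in this assay, because the other value shown is a limit (the limit of > 5000 nM in this assay, at which 1 of the 2 values shown sits).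

Compound 3, `CN(C)CCCCCCN(C)C1=Nc2ccccc2C(CC(=O)NCc2ccccc2)N1c1ccc(-c2ccccc2)cc1`, has not yet been measured in this assay. It differs from compound 2 in one place: 2-(dimethylamino)ethyl in place of dimethylamino on a saturated chain carbon, four bonds along the chain from an amine nitrogen. The group at the end of the chain stays the same and the saturated chain simply grows longer. No step between two measured compounds is shown here, and nothing among the measured compounds tells how such a lengthening shifts the read-out. The step from compound 2 to compound 3 in this assay is expected to be small, in no clear direction, and within the scatter, which the estimate a 1.0-fold higher number from compound 2 to compound 3 (0.00 log units; within the scatter) expresses. Compound 3 is expected to give about 4000 nM in this assay, with an estimated range from 1500 nM to 12000 nM, and a fair chance that only a limit is reported.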

Compound 3, half-maximal inhibitory concentration: 1740 nM
For compound 3 the middle estimate is 2.3-fold (0.36 log units) above the measured one, and the stated range covers the measured number.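

In this assay, the change from dimethylamino to 2-(dimethylamino)ethyl on a saturated chain carbon, four bonds along the chain from an amine nitrogen, gives a 2.3-fold lower number from compound 2 to compound 3 (0.36 log units; beyond the scatter). Among these compounds, this is the first measured step at this position, and it shows that the length of the saturated chain alone can move the read-out beyond the usual scatter, even with the same group at its end. The change is modest and points towards a stronger inhibitor, but it rests on one pair of compounds, so it gives a single observation rather than a trend, and it says nothing about the reason for the shift.

Compound 1 adds no further step, because its value is a limit and not a number: the limit of > 5000 nM in this assay, at which 1 of the 3 values shown sits.

On these data alone, whether a still longer chain would bring a further fall in the number or a reversal remains open, as does whether a cyclic amine such as piperidine at the end of the chain, in place of the dimethylamino group, would follow the same course.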